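Compound 2 gains a 5-(nitrooxy)pentyl group

The source may report more compounds than this note shows. Statements on the series, on what has been measured and on what is new or still open speak of the compounds shown alone.

Of the compounds shown here, three have so far been tested in a functional assay on NCI-H1792 cells (Homo sapiens) for cytotoxicity, read by resazurin assay, with a stated time of 72 h (on this read-out lower numbers stand for stronger inhibition and higher numbers for weaker inhibition), and they give a small but useful picture. Compound 1 `O=C(/C=C/c1ccc(OCCCCCO[N+](=O)[O-])c(O)c1)OCCCCCO[N+](=O)[O-]` gives > 50000 nM as a limit of the assay and not a number. Compound 2 `COc1cc(/C=C/C(=O)OCCCCCO[N+](=O)[O-])ccc1O` gives 13000 nM as the lower of the two actual numbers, while compound 3 `COc1cc(/C=C/C(=O)OCCCO[N+](=O)[O-])ccc1O` gives 28500 nM on the same test.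

Compound 4 `COc1cc(/C=C/C(=O)OCCCCCO[N+](=O)[O-])ccc1OCCCCCO[N+](=O)[O-]` differs from compound 2 in one place. The change is 5-(nitrooxy)pentyl in place of hydrogen on an oxygen on an aromatic ring and it turns hydroxy into (5-(nitrooxy)pentyl)oxy on an aromatic ring.

Within the data shown here, the only measured step is a 2.2-fold higher number from compound 2 to compound 3 (0.34 log units; beyond the scatter) and it is modest, though beyond the scatter. It lies on a different chain from the new group, so it serves only as a guide to size. Compound 1 also carries 5-(nitrooxy)pentyl on an oxygen on an aromatic ring, and its > 50000 nM stands as a limit in this assay without a number. That points toward weaker inhibition, not stronger.

A modest move is therefore expected, namely a 2.2-fold higher number from compound 2 to compound 4 (0.33 log units; beyond the scatter) toward a higher number. For compound 4 the estimate is 28000 nM with an expected range from 11000 nM to 50000 nM on this read-out.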

Compound 4, half-maximal inhibitory concentration: > 50000 nM
Compound 4: only a limit was reported; the forecaster's own chance of this, stated with the estimate: 35%; middle value at least 1.7-fold (0.25 log units) from the limit.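

In this assay compound 4 gives > 50000 nM, which is a limit of the assay and not a number. Even so, the change from hydroxy to (5-(nitrooxy)pentyl)oxy gives an at least 3.8-fold higher number from compound 2 to compound 4 (0.58 log units; beyond the scatter), the first direct reading at this oxygen on the aromatic ring, and it shows that this 5-(nitrooxy)pentyl group weakens inhibition by more than the usual scatter rather than leaving it unchanged. On these data alone, the step between compound 1 and compound 4 cannot be read, and the true size of the loss from compound 2 stays unknown, as the result reaches the same ceiling as compound 1: the limit of > 50000 nM in this assay, at which 2 of the 4 values shown sit.

The compounds shown cannot separate the effect of losing the hydrogen on this oxygen from the effect of the chain attached in its place, or the effect of the chain itself from that of its nitrooxy end. A plain pentyl group, a short ethyl group or a pentyl chain ending in an amine on this oxygen would each address a different part of that question, and any of them might give a real number rather than a limit.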